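Piperazine for morpholine in a fused amidine series

The source may report more compounds than this note shows. Statements on the series, on what has been measured and on what is new or still open speak of the compounds shown alone.

Measured so far:
compound 1 `COC(=O)CC1c2ccccc2N=C(N2CCOCC2)N1C(C)C`, about 0%
compound 2 `COC(=O)CC1c2ccccc2N=C(N2CCN(C)CC2)N1C(C)C`, about 0%
compound 3 `O=C(O)CC1c2ccccc2N=C(N2CCOCC2)N1c1ccccc1`, 9%

All three have been run in a functional assay on cells (Oocyte) for inhibition of Voltage-dependent T-type calcium channel subunit alpha-1H (Homo sapiens), tested at 100 uM; a lower number here means less inhibition, a higher number more inhibition at the concentration tested (going by the name of the read-out). Compound 1 and compound 2 differ in one place, (4-methylpiperazin-1-yl in place of morpholin-4-yl on a carbon with a double bond to nitrogen), and the read-out is flat: no change at the digits printed from compound 1 to compound 2 (within the scatter). Compound 3 carries a different core; how it differs from compound 1 is not broken down here. Compound 3 shows the highest of the three numbers, yet its gaps to compound 1 and to compound 2 both sit within the scatter, so no order among the three can be read from this assay.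

Compound 4 `CN1CCN(C2=Nc3ccccc3C(CC(=O)O)N2c2ccccc2)CC1` is not yet measured. It stands to compound 3 as compound 2 stands to compound 1: 4-methylpiperazin-1-yl in place of morpholin-4-yl on a carbon with a double bond to nitrogen. The two place descriptions are not identical, since in compound 3 the ring atom next to the exchange bears a phenyl group and the more distant one a carboxymethyl group, whereas in compound 1 those positions carry an isopropyl group and a (methoxycarbonyl)methyl group, so this is the same kind of change rather than the same change.

The expectation for compound 4 rests on compound 1 and compound 2, where the swap gave no change at the digits printed from compound 1 to compound 2 (within the scatter); a step of no change at the digits printed from compound 3 to compound 4 (within the scatter) is therefore expected. Compound 4 is estimated at 9% in this assay, with a likely range from 0% to 25%.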

Compound 4, a percentage reported as inhibition, at one concentration (the size of the read-out at that concentration, not a potency): 15%
Compound 4: the middle estimate sits 6 percentage points below what was measured; the measured number falls inside the stated range.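

In this assay, placing 4-methylpiperazin-1-yl where morpholin-4-yl stood on the core bearing phenyl and carboxymethyl gives a number 6 percentage points higher from compound 3 to compound 4 (within the scatter), and the step can be set directly beside the one on the core of compound 1: the same change on two cores in this assay, no change at the digits printed (within the scatter) from compound 1 to compound 2 and a number 6 percentage points higher (within the scatter) from compound 3 to compound 4, 6 percentage points apart, within the scatter of two such steps. As far as this read-out can tell, the flat result for this exchange therefore carries from the core of compound 1 to the core of compound 3, with no sign that the outcome depends on the core. This does not show that the exchange is without effect on the channel in general: the comparison rests on just two pairs read at one tested concentration, all with little inhibition, where compound 4 gives 15%, so a real difference between the cores that is smaller than the scatter would go unseen.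

Open, as far as these compounds go, is whether a different group on the same carbon, such as piperidin-1-yl, 4-acetylpiperazin-1-yl or an open-chain dimethylamino group, would move the read-out beyond the scatter. Also open, from the compounds shown here alone, is what a primary amide or a longer chain would do in place of carboxymethyl, and how the ester and the acid compare on an otherwise unchanged core, as compound 1 and compound 3 differ in more than one place.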